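Going from a four-membered ring to an aminophenyl group

The source may hold more compounds than are shown below. What is called first, only, known or untested is meant among the compounds shown, and "the series" means these compounds.

Measured so far:
compound 1 `Oc1ccc(CNc2cc(C(F)(F)F)cc3[nH]ncc23)cc1` gives 81%
compound 2 `O=C(O)c1cccc(CNc2cc(C(F)(F)F)cc3[nH]ncc23)c1` gives 17%
compound 3 `FC(F)(F)c1cc(NCC2CNC2)c2cn[nH]c2c1` gives 22%

In an assay for inhibition of Indoleamine 2,3-dioxygenase 1 (Homo sapiens), with stated times of 10 min and 60 min, tested at 100 uM (on this read-out lower numbers stand for a weaker effect and higher numbers for a stronger effect at the one concentration tested), compound 3 stands second highest of the three; its nearest neighbour is compound 2, within the scatter, while compound 1 lies far above it. Compound 4 `Nc1cccc(CNc2cc(C(F)(F)F)cc3[nH]ncc23)c1` has not yet been measured. It differs from compound 3 in one place: 3-aminophenyl in place of azetidin-3-yl on a saturated chain carbon bound to a nitrogen on an aromatic ring. Going by the values given here, one measured step bears on this change: a number 59 percentage points lower from compound 1 to compound 3 (beyond the scatter) shows that trading an aromatic ring for azetidin-3-yl cost a great deal. Compound 4 goes the other way, back to an aromatic ring, though with a different group on it than compound 1, and compound 2, also aromatic, gave 17%. Therefore the expected step is estimated as a number 23 percentage points higher from compound 3 to compound 4 (beyond the scatter), though its exact size is uncertain. Compound 4 is estimated at 45%, likely between 15% and 78%.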

Compound 4, a percentage reported as inhibition, at one concentration (the size of the read-out at that concentration, not a potency): 55%
The estimate for compound 4 lay 10 percentage points below the measured number, within the range that was stated.
By their numbers in this assay, from the lowest: compounds 2 and 3 (each within the scatter of the next); then compound 4; then compound 1.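

In this assay, an aromatic ring at this place can restore much of what azetidin-3-yl lacks (a number 33 percentage points higher from compound 3 to compound 4 (beyond the scatter)), so the low number of compound 2 does not condemn aromatic rings here. The group on the ring matters, with amino in place of carboxy giving a clear gain (a number 38 percentage points higher from compound 2 to compound 4 (beyond the scatter)), yet 3-aminophenyl still falls short of 4-hydroxyphenyl (a number 26 percentage points lower from compound 1 to compound 4 (beyond the scatter)). Nothing available explains these differences. Still open, as far as these compounds go, is whether that shortfall follows the group or its ring position, which 4-aminophenyl or 3-hydroxyphenyl could separate.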